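Aryl swap at the pyridine core, heteroaryl position

The source may hold more compounds than are shown below. What is called first, only, known or untested is meant among the compounds shown, and "the series" means these compounds.

Compound 1 `Oc1cccc(-c2cc(-c3cccs3)cc(-c3cccc(O)c3)n2)c1` gives 3480 nM in a functional assay on HCT-15 cells (Homo sapiens) for cytotoxicity, read by CCK-8 assay; a higher number here means a weaker inhibitor, a lower number a stronger inhibitor. Compound 2 `Oc1cccc(-c2cc(-c3ccoc3)cc(-c3cccc(O)c3)n2)c1` gives 1020 nM in this assay, and compound 3 `Oc1ccc(-c2cc(-c3ccoc3)cc(-c3cccc(O)c3)n2)cc1` gives 930 nM. Compound 2 thus stands second highest of the three numbers; its step of a 1.1-fold lower number from compound 2 to compound 3 (0.04 log units; within the scatter) is within the scatter, while the step of a 3.4-fold lower number from compound 1 to compound 2 (0.53 log units; beyond the scatter) is the only one beyond it. Compound 4 `Oc1cccc(-c2cc(-c3cccnc3)cc(-c3cccc(O)c3)n2)c1` is not yet measured; it differs from compound 2 by pyridin-3-yl in place of furan-3-yl on an aromatic carbon. Within the data shown here, the only measured step touching this position is the heteroaryl exchange from compound 1 to compound 2, which was modest; no measured pair exchanges a five-membered for a six-membered ring, so the direction is open. A step of roughly that size in either direction, or none beyond the scatter, is the expectation, and the estimate for compound 4 in this assay is 1300 nM, with a range from 450 nM to 3800 nM, meaning an expected step of a 1.3-fold higher number from compound 2 to compound 4 (0.11 log units; within the scatter).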

Compound 4, half-maximal inhibitory concentration: > 50000 nM
Compound 4 was reported as a limit; the forecaster's own chance of this, stated with the estimate: 5%; middle value at least 38-fold (1.58 log units) from the limit.
By their numbers in this assay, from the lowest: compounds 3 and 2 (each within the scatter of the next); then compound 1. At a limit, above all of these: compound 4.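

In this assay, compound 4 is reported only as a limit: the limit of > 50000 nM in this assay, at which 1 of the 4 values shown sits.

At this position, the heteroaryl group can therefore matter far more than the modest exchange between the two five-membered rings suggested, with steps of an at least 49-fold higher number from compound 2 to compound 4 (1.69 log units; beyond the scatter) and an at least 14-fold higher number from compound 1 to compound 4 (1.15 log units; beyond the scatter), both resting on that limit. Among the compounds shown, the furan-3-yl and thiophen-2-yl compounds keep a measurable number, while pyridin-3-yl, on the carbon opposite the ring nitrogen, does not.

On these data alone, whether this loss follows the six-membered ring or its nitrogen stays open, and a plain phenyl group at this position would separate the two. Also open, as far as these compounds go, is whether pyridin-3-yl gives the same outcome alongside the 4-hydroxyphenyl group of compound 3.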